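From compound 2 to compound 3: a shifted halogen

The source may hold more compounds than are shown below. What is called first, only, known or untested is meant among the compounds shown, and "the series" means these compounds.

Compound 1 `O=C(Nc1cc(-c2ccccc2)nn1-c1ccccc1)c1ccc(F)cc1` and compound 2 `O=C(Nc1cc(-c2ccccc2)nn1-c1ccccc1)c1cccc(Cl)c1` share one core and differ only in the ring attached to the carbonyl carbon. In an assay on CHO cells with metabotropic glutamate receptor 5 (Homo sapiens) as the target (on this read-out higher numbers stand for an effect only at larger amounts of compound and lower numbers for an effect already at smaller amounts), compound 1 gives 30 nM, and compound 2 gives 40 nM. The step of a 1.3-fold higher number from compound 1 to compound 2 (0.12 log units; within the scatter) is small. Among the compounds with values here, of the two numbers measured so far compound 2 holds the higher one, though its distance to compound 1 lies within the scatter, so the two cannot be ranked. Compound 3 `O=C(Nc1cc(-c2ccccc2)nn1-c1ccccc1)c1ccccc1F` is not yet measured; it carries 2-fluorophenyl in place of 3-chlorophenyl on a carbonyl carbon. Within the data shown here, the only measured step that bears on this change is a 1.3-fold higher number from compound 1 to compound 2 (0.12 log units; within the scatter), where one halogen-bearing phenyl ring replaced another without a shift beyond the scatter. By the same token the step of no change at the digits printed from compound 2 to compound 3 (within the scatter) is expected to stay small, with no clear direction. Compound 3 is therefore estimated at 40 nM in this assay, with a range from 15 nM to 120 nM.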

Compound 3, half-maximal effective concentration: 75 nM
The estimate for compound 3 lay 1.9-fold (0.27 log units) below the measured number; the range from low to high includes it.
By their numbers in this assay, from the lowest: compounds 1, 2 and 3 (each within the scatter of the next, the first and the last beyond it).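

In this assay, within the data shown here, the change to 2-fluorophenyl in place of 4-fluorophenyl on the carbonyl carbon gives a 2.5-fold higher number from compound 1 to compound 3 (0.40 log units; beyond the scatter) and is the first step to clear the scatter. The change to 2-fluorophenyl in place of 3-chlorophenyl gives a 1.9-fold higher number from compound 2 to compound 3 (0.27 log units; within the scatter) and leaves these two compounds unranked. The ring on the carbonyl carbon can therefore shift the number modestly, but of the three compounds only compound 1 and compound 3 can be told apart. Nothing available here explains that shift. Compound 2 and compound 3 differ in both the halogen and its place on the ring, so the compounds shown cannot separate those two changes. Going by these compounds, how this ring would respond to a group other than a halogen, such as a methoxy group or an amine, also stays open.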